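Aryl swap on the shared core: cytotoxicity notes

This account rests on a few compounds, and the source may have more. Where it says the series, first, only, none or still open, it means among the compounds named here.

compound 1 `COc1nc(-c2ccc(C#N)cc2)ccc1[C@@H](c1ccccc1)[C@@](O)(CCN(C)C)c1cccc2ccccc12`: > 50 ug/mL, a limit
compound 2 `COc1nc(-c2cccc(F)c2)ccc1[C@@H](c1ccccc1)[C@@](O)(CCN(C)C)c1cccc2ccccc12`: > 50 ug/mL, a limit
compound 3 `COc1nc(-c2ccsc2)ccc1[C@@H](c1ccccc1)[C@@](O)(CCN(C)C)c1cccc2ccccc12`: 24.4 ug/mL

Within the data shown here, in a toxicity assay on Vero cells (Chlorocebus sabaeus) for cytotoxicity (on this read-out lower numbers stand for higher toxicity in this test and higher numbers for lower toxicity in this test), compound 3 gives the only number in the set. For compound 1 the value is a limit of the assay. For compound 2 the value is likewise a limit. The two measured steps that reach compound 3 are an at least 2.0-fold lower number from compound 1 to compound 3 (0.31 log units; beyond the scatter) and an at least 2.0-fold lower number from compound 2 to compound 3 (0.31 log units; beyond the scatter); their full size is not readable because of the limit of > 50 ug/mL in this assay, at which 2 of the 3 values shown sit.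

Compound 4 `COc1nc(-c2ccc(Cl)c(F)c2)ccc1[C@@H](c1ccccc1)[C@@](O)(CCN(C)C)c1cccc2ccccc12` differs from compound 3 in one place: 4-chloro-3-fluorophenyl in place of thiophen-3-yl on an aromatic carbon. Both measured steps moved a six-membered carbon ring to thiophen-3-yl and lowered the number, so the reverse direction is expected here, a higher number in this assay, plausibly back at the limit.

Compound 4 is therefore estimated at 45 ug/mL, range 20 ug/mL to 80 ug/mL, which means an expected 1.8-fold higher number from compound 3 to compound 4 (0.27 log units; within the scatter).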

Compound 4, half-maximal cytotoxic concentration: > 50 ug/mL
Compound 4 gave a limit, no number; the forecaster's own chance of this, stated with the estimate: 55%; middle value at least 1.1-fold (0.04 log units) from the limit.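

The change to 4-chloro-3-fluorophenyl on this aromatic carbon gives, in this assay, an at least 2.0-fold higher number from compound 3 to compound 4 (0.31 log units; beyond the scatter). Compound 4 gives only a limit, > 50 ug/mL, so adding chloro to the 3-fluorophenyl group of compound 2 brings no number into view, and thiophen-3-yl stays apart from all three six-membered carbon rings shown. The steps from compound 1 and compound 2 to compound 4 cannot be read: the limit of > 50 ug/mL in this assay, at which 3 of the 4 values shown sit.

Open, as far as these compounds go, is whether the lower number belongs to thiophen-3-yl alone or to five-membered aromatic rings generally, as furan-3-yl would show, and what a phenyl ring carrying an amine would give. From the compounds shown here alone, how far compound 1, compound 2 and compound 4 lie past the limit also stays open.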